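A few compounds are considered here, and "the series" means these few. Any claim that something is new, unique, unknown or untested is made for them only; others in the source may bear on it.

Of the compounds shown here, three with a shared core have already been tested for their power to slow the growth of cultured cancer cells. Compound 1, `COc1ccc(Cn2cc(CNC(=O)c3cn(-c4ccccc4)nc3-c3ccc(Cl)cc3)nn2)cc1OC`, compound 2, `COc1cc(Cn2cc(CNC(=O)c3cn(-c4ccccc4)nc3-c3ccc(Cl)cc3)nn2)cc(OC)c1`, and compound 3, `COc1ccc(-c2nn(-c3ccccc3)cc2C(=O)NCc2cn(Cc3ccc(OC)c(OC)c3)nn2)cc1`, were each run in a functional assay on HeLa cells (Homo sapiens) for antiproliferative activity, read by sulforhodamine B assay, with a stated time of 48 h; on this read-out higher numbers stand for weaker inhibition of growth and lower numbers for stronger inhibition of growth. In this assay compound 1 gives 200 nM. In this assay compound 2 gives 730 nM, and compound 3 gives 800 nM; the values of compound 2 and compound 3 lie within the usual scatter of each other.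

Two single changes link these results. Compound 2 differs from compound 1 by 3,5-dimethoxyphenyl in place of 3,4-dimethoxyphenyl on a saturated chain carbon bound to an aromatic nitrogen, and this change made a step of a 3.7-fold higher number from compound 1 to compound 2 (0.56 log units; beyond the scatter). Compound 3 differs from compound 1 by methoxy in place of chloro on an aromatic carbon, which made a step of a 4.0-fold higher number from compound 1 to compound 3 (0.60 log units; beyond the scatter).

Compound 4, `COc1ccc(-c2nn(-c3ccccc3)cc2C(=O)NCc2cn(Cc3cc(OC)cc(OC)c3)nn2)cc1`, has not yet been measured. It differs from compound 3 by 3,5-dimethoxyphenyl in place of 3,4-dimethoxyphenyl on a saturated chain carbon bound to an aromatic nitrogen, the same change, at the same place, that links compound 1 to compound 2. Going by the values given here, only that one earlier pair shows how this change behaves, so the expectation rests on it alone. Carrying the step seen in compound 1 and compound 2 over to compound 3 gives an expected step of a 3.8-fold higher number from compound 3 to compound 4 (0.57 log units; beyond the scatter), set beside the measured 3.7-fold higher number from compound 1 to compound 2 (0.56 log units; beyond the scatter). On that basis compound 4 is estimated to give 3000 nM in this assay, with a plausible range from 1400 nM to 6500 nM.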

Compound 4, concentration for 50% growth inhibition: 12400 nM
Compound 4: middle estimate off by 4.1-fold (0.62 log units), on the low side; the whole stated range lies below it.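

In this assay the swap of 3,4-dimethoxyphenyl for 3,5-dimethoxyphenyl weakened growth inhibition on both cores, but it did not carry over at a constant size: on the core with methoxy it gave a 16-fold higher number from compound 3 to compound 4 (1.19 log units; beyond the scatter) and that is clearly more than it gave on the core with chloro: the same change on two cores in this assay, a 3.7-fold higher number (0.56 log units; beyond the scatter) from compound 1 to compound 2 and a 16-fold higher number (1.19 log units; beyond the scatter) from compound 3 to compound 4, 4.2-fold (0.63 log units) apart, beyond the scatter of two such steps.

Read the other way round, methoxy in place of chloro gave a 17-fold higher number from compound 2 to compound 4 (1.23 log units; beyond the scatter) and this step too depends on which dimethoxyphenyl group is present: the same change on two cores in this assay, a 4.0-fold higher number (0.60 log units; beyond the scatter) from compound 1 to compound 3 and a 17-fold higher number (1.23 log units; beyond the scatter) from compound 2 to compound 4, 4.2-fold (0.63 log units) apart, beyond the scatter of two such steps.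

So in these four compounds the direction of each change held while its size depended on the other group, which means the two effects cannot simply be added together; this rests on a single set of four compounds, however, and does not show why the steps differ or whether the same holds elsewhere in the series.

Still open, on these data alone, is how the change would behave on cores carrying fluoro or methyl where chloro or methoxy now stands. Also open, as far as these compounds go, is what a benzyl group with only one methoxy, or with none, would do at the same place.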